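A few compounds are considered here, and "the series" means these few. Any claim that something is new, unique, unknown or untested is made for them only; others in the source may bear on it.

Measured in an ADME assay (liver) for pharmacokinetics, with Liver microsome (Homo sapiens) as the target, using microsomes; on this read-out higher numbers stand for a longer-lived compound and lower numbers for a shorter-lived compound:
Compound 1, `CCCOC(=O)/C=C/c1ccc(NC(=O)C2(NC(=O)c3ccc4c(C5CCCC5)c(-c5ncc(Cl)cn5)n(C)c4c3)CCC2)cc1OCC`: > 5 h, a limit of the assay rather than a number.
Compound 2, `CCCCCCOC(=O)/C=C/c1ccc(NC(=O)C2(NC(=O)c3ccc4c(C5CCCC5)c(-c5ncc(Cl)cn5)n(C)c4c3)CCC2)cc1OCC`: 17.9 h.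
Compound 3, `CCOc1cc(NC(=O)C2(NC(=O)c3ccc4c(C5CCCC5)c(-c5ncc(Cl)cn5)n(C)c4c3)CCC2)ccc1/C=C/C(=O)OCC(=O)OC`: 2.1 h.

Compound 3 has the lowest number shown; its nearest neighbour is compound 2, reached by an 8.5-fold lower number from compound 2 to compound 3 (0.93 log units; beyond the scatter). The change to compound 4, `CCOc1cc(NC(=O)C2(NC(=O)c3ccc4c(C5CCCC5)c(-c5ncc(Cl)cn5)n(C)c4c3)CCC2)ccc1/C=C/C(=O)OCC(=O)OCc1ccc(Cl)cc1`, is 4-chlorophenyl in place of hydrogen on a saturated chain carbon bound to an oxygen next to a carbonyl group. The measured steps at this ester group are an at least 2.3-fold lower number from compound 1 to compound 3 (0.37 log units; beyond the scatter) and an 8.5-fold lower number from compound 2 to compound 3 (0.93 log units; beyond the scatter), both lowering the number when a methoxycarbonyl replaced an alkyl group; the step that the limit leaves unreadable from compound 1 to compound 2 cannot be read because of the limit of > 5 h in this assay, at which 1 of the 3 values shown sits. The new change runs in the opposite direction, back toward the esters of compounds 1 and 2, so a modest rise is expected: a 1.7-fold higher number from compound 3 to compound 4 (0.22 log units; within the scatter). Compound 4 is estimated at 3.5 h, between 1.2 h and 10 h.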

Compound 4, half-life: 5.62 h
For compound 4 the middle estimate is 1.6-fold (0.21 log units) below the measured one, and the stated range covers the measured number.
By their numbers in this assay, from the lowest: compound 3; then compound 4; then compound 2.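

In this assay, the far end of this ester can still move the number: going from methyl to 4-chlorobenzyl gives a 2.7-fold higher number from compound 3 to compound 4 (0.43 log units; beyond the scatter). The aromatic ring does not bring the number back to that of the plain hexyl ester, with a 3.2-fold lower number from compound 2 to compound 4 (0.50 log units; beyond the scatter). The step from compound 1 to compound 4 cannot be read, because compound 1 carries a limit rather than a number: the limit of > 5 h in this assay, at which 1 of the 4 values shown sits.

The compounds shown do not separate the part played by the chlorine from that of the ring, which an unsubstituted benzyl ester would address. As far as these compounds go, how a carboxylic acid at this position would read also stays open.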